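The source may report more compounds than this note shows. Statements on the series, on what has been measured and on what is new or still open speak of the compounds shown alone.

Measured compounds:
compound 1 `CCOc1ccc(-n2nnc3n[nH]c(NC)c3c2=O)cc1` gives 7010 nM in a functional assay on Huh-7 cells (Homo sapiens) for cytotoxicity, read by resazurin assay, with a stated time of 48 h; a higher number here means a weaker inhibitor, a lower number a stronger inhibitor
compound 2 `CCOc1ccc(-n2nnc3n[nH]c(Nc4ccccc4)c3c2=O)cc1` gives 9390 nM
compound 3 `CCOc1ccc(NC(=O)/C(C#N)=C(\Nc2ccccc2)SC)cc1` gives 25300 nM

Compounds 1 and 2 share a core. The change between them, (methyl in place of phenyl on a nitrogen on an aromatic ring), gives a 1.3-fold lower number from compound 2 to compound 1 (0.13 log units; within the scatter). Compound 3 carries a different core; how the core of compound 3 differs from the core of compound 2 is not broken down here. Compound 3 gives the highest number of the three, beyond the scatter against compound 2 and further still against compound 1.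

Compound 4 `CCOc1ccc(NC(=O)/C(C#N)=C(\NC)SC)cc1` is not yet measured and derives from compound 3 by methyl in place of phenyl on an amine nitrogen. This is the same kind of change as from compound 2 to compound 1, though the place differs: in compound 3 it sits on an amine nitrogen whose other neighbour is a double-bonded chain carbon, in compound 2 on a nitrogen on an aromatic ring whose other neighbour is an aromatic carbon. Because the measured instance a 1.3-fold lower number from compound 2 to compound 1 (0.13 log units; within the scatter) stays within the scatter, compound 4 is expected to show a step of a 1.3-fold lower number from compound 3 to compound 4 (0.10 log units; within the scatter) in this assay. The estimate for compound 4 is 20000 nM, between 9000 nM and 45000 nM.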

Compound 4, half-maximal inhibitory concentration: 5780 nM
For compound 4 the middle estimate is 3.5-fold (0.54 log units) above the measured one; the whole stated range lies above it.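

Methyl in place of phenyl on an amine nitrogen gives a 4.4-fold lower number from compound 3 to compound 4 (0.64 log units; beyond the scatter) in this assay. The same change therefore cannot be carried at one fixed size from one core to the other in this series: the same change on two cores in this assay, a 1.3-fold lower number (0.13 log units; within the scatter) from compound 2 to compound 1 and a 4.4-fold lower number (0.64 log units; beyond the scatter) from compound 3 to compound 4, 3.3-fold (0.51 log units) apart, beyond the scatter of two such steps This rests on a single pair of steps on two cores, so it does not show what sets the gap or how the change would behave on a third core.

Open, as far as these compounds go, is whether an ethyl group, a longer chain or a cyclohexyl group at the place of the change would track the methyl or the phenyl results on either core. Also open, from the compounds shown here alone, is whether the gap between the two cores holds for such groups in this assay.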